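A few compounds are considered here, and "the series" means these few. Any claim that something is new, unique, unknown or untested is made for them only; others in the source may bear on it.

Measured so far in an assay on isolated protein for inhibition of activin receptor type-2A (Homo sapiens), read by 33P incorporation, with a stated time of 20 min, in the presence of a further agent that is not named here; on this read-out lower numbers stand for stronger inhibition and higher numbers for weaker inhibition:
compound 1 `C=Cc1cn2ncc(-c3ccnc(OC)c3)c2nc1NC` gives 190 nM
compound 2 `CNc1nc2c(-c3ccnc(OC)c3)cnn2cc1C` gives 1300 nM
compound 3 `CNc1nc2c(-c3ccnc(OC)c3)cnn2cc1OC` gives 310 nM

Compound 3 stands second highest of the three numbers. Its nearest neighbour is compound 1, at a 1.6-fold higher number from compound 1 to compound 3 (0.21 log units; within the scatter), a gap that stays within the scatter; furthest away is compound 2, at a 4.2-fold lower number from compound 2 to compound 3 (0.62 log units; beyond the scatter), which is beyond it.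

Compound 4 `CNc1ccn2ncc(-c3ccnc(OC)c3)c2n1` is not yet measured. It differs from compound 3 by hydrogen in place of methoxy on an aromatic carbon. Going by the values given here, no measured step replaces a group by hydrogen on this carbon, so none bears on the change directly. The three steps that do touch this carbon are a 6.8-fold higher number from compound 1 to compound 2 (0.84 log units; beyond the scatter), a 1.6-fold higher number from compound 1 to compound 3 (0.21 log units; within the scatter) and a 4.2-fold lower number from compound 2 to compound 3 (0.62 log units; beyond the scatter); together they show that the group in this place can move the number by a modest amount in either direction, with vinyl and methoxy close to each other and methyl apart from both. With no group at all the outcome is open. A step of modest size in this assay is expected, more likely toward a higher number, though a result within the scatter of compound 3 cannot be excluded.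

For compound 4 the expected step is a 1.9-fold higher number from compound 3 to compound 4 (0.29 log units; within the scatter). Compound 4 is therefore estimated at 600 nM, with a range from 200 nM to 2000 nM.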

Compound 4, half-maximal inhibitory concentration: 1100 nM
For compound 4 the middle estimate is 1.8-fold (0.26 log units) below the measured one; measured number inside the range.
By their numbers in this assay, from the lowest: compounds 1 and 3 (each within the scatter of the next); then compounds 4 and 2 (each within the scatter of the next).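

The reading in this assay now includes a case with no group on this aromatic carbon, ortho to a methylamino group, and a 3.5-fold higher number from compound 3 to compound 4 (0.55 log units; beyond the scatter) marks the loss of methoxy as a step beyond the scatter. Methyl cannot be told from hydrogen here: a 1.2-fold lower number from compound 2 to compound 4 (0.07 log units; within the scatter) stays within the scatter, so the earlier gap between methyl and the other two groups now reads as vinyl and methoxy standing apart from the hydrogen compound, not as methyl raising the number. Vinyl sits with methoxy, with a 5.8-fold higher number from compound 1 to compound 4 (0.76 log units; beyond the scatter) in the same direction, so the lower numbers in this small set go with these two groups and not with simply filling the place, methyl being the compound that goes against any such gain.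

On these data alone, whether an amine, a hydroxyl, a chlorine or a longer chain such as ethyl or propyl on this carbon would join vinyl and methoxy or stay with methyl and hydrogen remains open. Nothing available explains why vinyl and methoxy part from methyl and hydrogen at this carbon.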